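The source may hold more compounds than are shown below. What is called first, only, known or untested is meant among the compounds shown, and "the series" means these compounds.

Measured compounds:
compound 1, `CCN(CC)S(=O)(=O)c1ccc(S(=O)(=O)N2CCC[C@@H](C(=O)N3CCC(F)(F)CC3)C2)cc1`, half-life 0.0457 h
compound 2, `O=C([C@@H]1CCCN(S(=O)(=O)c2ccc(S(=O)(=O)C3CCC3)cc2)C1)N1CCC(F)(F)CC1`, half-life > 1 h

For the measured compounds named here, in an ADME assay on microsomes from liver (Homo sapiens) for metabolic stability, read by LC-MS, using NADPH, with a stated time of 60 min, tested at 10 uM (a lower number here means that the compound disappears faster, a higher number that the compound lasts longer), compound 1 gives 0.0457 h, the only plain number among the two results. Compound 2 gives > 1 h, which is a limit of the assay rather than a number (the limit of > 1 h in this assay, at which 1 of the 2 values shown sits). Going by the values given here, the single measured step, an at least 21-fold higher number from compound 1 to compound 2 (1.34 log units; beyond the scatter), concerns the sulfonyl end of the shared core.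

Compound 3, `CCN(CC)S(=O)(=O)c1ccc(S(=O)(=O)N2CCC[C@@H](C(=O)NC3COC3)C2)cc1`, differs from compound 1 at the other end of the molecule: (oxetan-3-yl)amino in place of 4,4-difluoropiperidin-1-yl on a carbonyl carbon. Among the compounds with values here, the measured step touches neither the carbonyl carbon nor the groups attached to it, so no measured step bears on this change, and there is no evidence here on what happens when the 4,4-difluoropiperidin-1-yl group gives way to (oxetan-3-yl)amino.

Without a relevant step, the expectation for compound 3 rests on compound 1 alone and is for no change beyond the scatter, giving a 1.3-fold higher number from compound 1 to compound 3 (0.12 log units; within the scatter). In this assay compound 3 is therefore estimated at 0.06 h, within a range of 0.02 h to 0.25 h.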

Compound 3, half-life: 0.308 h
For compound 3 the middle estimate is 5.1-fold (0.71 log units) below the measured one; the measured number lies above the stated range.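

The carbonyl end of the shared core, on which the earlier pair said nothing, also matters in this assay: with the diethylamino group on the sulfonyl sulfur left in place, the change on the carbonyl carbon gives a 6.7-fold higher number from compound 1 to compound 3 (0.83 log units; beyond the scatter) as its step. Compound 1 can therefore be moved towards a longer half-life from either end of the molecule, at the sulfonyl end as well as at the carbonyl end. The exchange alters several things at once, including the ring, the oxygen in place of the two fluorines and the new amide hydrogen, and nothing shown here separates these or accounts for the step.

As far as these compounds go, it remains open whether cyclobutyl on the sulfonyl sulfur and (oxetan-3-yl)amino on the carbonyl carbon would add to each other when present in one molecule. From the compounds shown here alone, it is equally open whether the step belongs to the oxetane ring itself, since a plain cyclobutylamino group, an unfluorinated piperidin-1-yl group or an open-chain dimethylamino group on the same carbonyl carbon would be needed to tell.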